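A few compounds are considered here, and "the series" means these few. Any claim that something is new, unique, unknown or untested is made for them only; others in the source may bear on it.

Measured compounds:
Compound 1, `CC(C)[C@H](NC(=O)COc1cccc2ccccc12)C(=O)N[C@@H](CC(=O)O)C(=O)COc1ccc(C#N)cc1`: in a functional assay on Jurkat cells (Homo sapiens) (a lower number here means a stronger inhibitor, a higher number a weaker inhibitor), compound 1 gives > 100000 nM, which is a limit of the assay rather than a number.
Compound 2, `CC(C)[C@H](NC(=O)COc1cccc2ccccc12)C(=O)N[C@@H](CC(=O)O)C(=O)COc1ccc(OC(F)(F)F)cc1`: in this assay compound 2 gives 29100 nM.
Compound 3, `CC(C)[C@H](NC(=O)COc1cccc2ccccc12)C(=O)N[C@@H](CC(=O)O)C(=O)COc1ccc(F)cc1F`: in this assay compound 3 gives 33200 nM.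

Compound 3 stands beside compound 2 among the two numbers shown; the step of a 1.1-fold higher number from compound 2 to compound 3 (0.06 log units; within the scatter) lies within the scatter, so the two cannot be told apart. Compound 1 sits at the limit of > 100000 nM in this assay, at which 1 of the 3 values shown sits. Compound 4, `CC(C)[C@H](NC(=O)COc1cccc2ccccc12)C(=O)N[C@@H](CC(=O)O)C(=O)COc1c(Cl)cccc1Cl`, is not yet measured and differs from compound 3 by 2,6-dichlorophenyl in place of 2,4-difluorophenyl on an oxygen on a saturated carbon. Among the measured compounds shown here, two measured steps bear on an aryl exchange at this oxygen: an at least 3.0-fold lower number from compound 1 to compound 3 (0.47 log units; beyond the scatter), beyond the scatter, and a 1.1-fold higher number from compound 2 to compound 3 (0.06 log units; within the scatter), within it. The halogenated-phenyl exchange from compound 2 to compound 3 moved nothing beyond the scatter, so for compound 4 a step of a 1.1-fold lower number from compound 3 to compound 4 (0.04 log units; within the scatter) is expected. Compound 4 is estimated at 30000 nM, within 10000 nM to 100000 nM.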

Compound 4, half-maximal inhibitory concentration: 3000 nM
Compound 4: middle estimate off by 10-fold (1.00 log units), on the high side, outside the stated range (below it).
By their numbers in this assay, from the lowest: compound 4; then compounds 2 and 3 (each within the scatter of the next). At a limit, above all of these: compound 1.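

The aryl group on this oxygen can move the number well beyond the scatter, which the exchange between compound 2 and compound 3 did not show: 2,6-dichlorophenyl gives an 11-fold lower number from compound 3 to compound 4 (1.04 log units; beyond the scatter) and a 9.7-fold lower number from compound 2 to compound 4 (0.99 log units; beyond the scatter). Against 4-cyanophenyl, the change gives an at least 33-fold lower number from compound 1 to compound 4 (1.52 log units; beyond the scatter). That step is only a bound, since compound 1 stands at a limit and not at a number: the limit of > 100000 nM in this assay, at which 1 of the 4 values shown sits.

Compound 4 differs from compound 3 in both halogen and ring placement, so the two stay unseparated. 2,4-Dichlorophenyl and 2,6-difluorophenyl would separate them, and 2,6-dimethylphenyl would test whether halogen is needed at all.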